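The source may hold more compounds than are shown below. What is called first, only, known or untested is meant among the compounds shown, and "the series" means these compounds.

Measured in a functional assay on MCF7 cells (Homo sapiens) for inhibition, read by MTT assay, with a stated time of 72 h; a lower number here means a stronger inhibitor, a higher number a weaker inhibitor:
- Compound 1 `C=CCSc1nc2nc(C)cc(Nc3cc(-c4ccccc4)[nH]n3)n2n1`: > 50000 nM, which is a limit of the assay and not a number.
- Compound 2 `Cc1ccc(CSc2nc3nc(C)cc(Nc4cc(-c5ccccc5)[nH]n4)n3n2)cc1`: 7290 nM.
- Compound 3 `Cc1cc(Nc2cc(-c3ccccc3)[nH]n2)n2nc(SCc3cccc4ccccc34)nc2n1`: 7560 nM.

Going by the values given here, compound 3 stands level with the only other measured number, a 1.0-fold higher number from compound 2 to compound 3 (0.02 log units; within the scatter). The next change gives compound 4 `Cc1cc(Nc2cc(-c3ccccc3)[nH]n2)n2nc(SCC3CC3)nc2n1`: cyclopropyl in place of naphthalen-1-yl on a saturated chain carbon bound to a sulfur, (cyclopropyl in place of naphthalen-1-yl on a saturated chain carbon bound to a sulfur). The closest evidence is the vinyl group of compound 1, which, like cyclopropyl, is not aromatic. Replacing that vinyl with naphthalen-1-yl gave an at least 6.6-fold lower number from compound 1 to compound 3 (0.82 log units; beyond the scatter), and replacing it with 4-methylphenyl gave an at least 6.8-fold lower number from compound 1 to compound 2 (0.83 log units; beyond the scatter). Both steps are beyond the scatter, while the exchange between the two aromatic groups was not. Removing the aromatic rings is therefore expected to reverse much of that gain in this assay, giving a higher number, and the assay may report only a limit. The expected change is a 4.0-fold higher number from compound 3 to compound 4 (0.60 log units; beyond the scatter). For compound 4 the estimated value is 30000 nM, with an expected range of 10000 nM to 60000 nM.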

Compound 4, half-maximal inhibitory concentration: > 50000 nM
Compound 4: a limit, no number (the forecaster's own chance of this, stated with the estimate: 45%); at least 1.6-fold (0.22 log units) between middle value and limit.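

In this assay, cyclopropyl in place of naphthalen-1-yl gave an at least 6.6-fold higher number from compound 3 to compound 4 (0.82 log units; beyond the scatter), and cyclopropyl in place of 4-methylphenyl gave an at least 6.8-fold higher number from compound 2 to compound 4 (0.83 log units; beyond the scatter). Going by these compounds alone, until now, vinyl was the only non-aromatic group on this saturated chain carbon bound to a sulfur, and cyclopropyl shows that a non-aromatic ring there also fails to match the two aromatic groups, so among the four compounds only those with aromatic groups, compound 2 and compound 3, give numbers. The step from compound 1 to compound 4 cannot be read, so vinyl and cyclopropyl cannot be ordered: the limit of > 50000 nM in this assay, at which 2 of the 4 values shown sit.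

Going by these compounds, it remains open whether a longer alkyl chain or an amine on this carbon would give a number rather than a limit. On these data alone, it is also open whether an unsubstituted phenyl would match compound 2.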